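A few compounds are considered here, and "the series" means these few. Any claim that something is new, unique, unknown or untested is made for them only; others in the source may bear on it.

Going by the values given here, compound 2 `CCN(CC)S(=O)(=O)N1CCN(c2ccc(OCC3CCN(C(=O)OC(C)C)CC3)cn2)CC1` gives the only number in a functional assay on CHO-K1 cells for agonist activity at Glucose-dependent insulinotropic receptor (Homo sapiens), read by a luciferase reporter, with a stated time of 5 h (on this read-out lower numbers stand for an effect already at smaller amounts and higher numbers for an effect only at larger amounts of compound), namely 1200 nM. Compound 1 `CC(C)NC(=O)CN1CCN(c2ccc(OCC3CCN(C(=O)OC(C)C)CC3)cn2)CC1` reaches only a limit in this assay, > 10000 nM (the limit of > 10000 nM in this assay, at which 1 of the 2 values shown sits). Compound 3 `CC(C)OC(=O)N1CCC(COc2ccc(N3CCN(S(=O)(=O)N4CCCCC4)CC3)nc2)CC1` differs from compound 2 by piperidin-1-yl in place of diethylamino on a sulfonyl sulfur. Among the compounds with values here, the single measured step, an at least 8.3-fold lower number from compound 1 to compound 2 (0.92 log units; beyond the scatter), exchanges the whole group on the ring nitrogen and does not test this smaller exchange on the sulfonyl sulfur. No change beyond the scatter is therefore expected in this assay, and the expected step for compound 3 is a 1.2-fold lower number from compound 2 to compound 3 (0.08 log units; within the scatter). Compound 3 is estimated at 1000 nM, within a range from 350 nM to 3000 nM.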

Compound 3, half-maximal effective concentration: 1000 nM
Compound 3: the middle estimate sits on the measured number at the digits printed, within the range that was stated.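

In this assay, the exchange on the sulfonyl sulfur gives a 1.2-fold lower number from compound 2 to compound 3 (0.08 log units; within the scatter), so the ring of piperidin-1-yl serves there as well as open-chain diethylamino. With a second sulfonyl group in hand, the gain over (isopropylcarbamoyl)methyl on the amine nitrogen in a ring recurs, as an at least 10-fold lower number from compound 1 to compound 3 (1.00 log units; beyond the scatter). The size of that step stays open-ended, since compound 1 stands at a limit: the limit of > 10000 nM in this assay, at which 1 of the 3 values shown sits.

From the compounds shown here alone, whether morpholin-4-yl or dimethylamino on the sulfonyl sulfur would hold this level remains open. So does whether any amine on that sulfur can move the number beyond the scatter.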